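Compound 4: phenethylcarbonyl in place of 3-phenylpropyl

The source may report more compounds than this note shows. Statements on the series, on what has been measured and on what is new or still open speak of the compounds shown alone.

Compound 1 `Cc1ccc(-c2c3c(nc(C)c2C(OC(C)(C)C)C(=O)O)CCN(CCCC2CCCC2)C3)cc1` - a limit (> 40000 nM)
Compound 2 `Cc1ccc(-c2c3c(nc(C)c2C(OC(C)(C)C)C(=O)O)CCN(Cc2ccccc2-c2ccccc2)C3)cc1` - a limit (> 40000 nM)
Compound 3 `Cc1ccc(-c2c3c(nc(C)c2[C@H](OC(C)(C)C)C(=O)O)CCN(CCCc2ccccc2)C3)cc1` - a limit (> 40000 nM)

These results come from an ADME assay on MT2 cells (Homo sapiens) for cytotoxicity, read by XTT assay, with a stated time of 4 days (on this read-out lower numbers stand for higher toxicity in this test and higher numbers for lower toxicity in this test), and none is an exact number. Compound 3 gives only a limit (> 40000 nM) and so sits where the whole set sits, at the limit of > 40000 nM in this assay, at which 3 of the 3 values shown sit. Compound 4 `Cc1ccc(-c2c3c(nc(C)c2[C@H](OC(C)(C)C)C(=O)O)CCN(C(=O)CCc2ccccc2)C3)cc1` differs from it by phenethylcarbonyl in place of 3-phenylpropyl on an amine nitrogen in a ring on that ring nitrogen. For the measured compounds named here, the one measured step, a step that the two limits leave unreadable from compound 1 to compound 2, offers no size to carry over. Given (the limit of > 40000 nM in this assay, at which 3 of the 3 values shown sit), no step beyond the scatter is expected in this assay, and no direction can be named. The expected step is a number no higher from compound 3 to compound 4 (the limit leaves the size open) and it will probably be reported only as a limit. For compound 4 the estimate is 40000 nM, with an expected range of 20000 nM to 80000 nM in this test.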

Compound 4, half-maximal cytotoxic concentration: > 40000 nM
Compound 4 gave a limit, no number; the forecaster's own chance of this, stated with the estimate: 85%; the middle value sits exactly at the limit.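

Compound 3 and compound 4 each give only a limit in this assay, not a number, so no step can be read between them: the limit of > 40000 nM in this assay, at which 4 of the 4 values shown sit.

From the compounds shown here alone, whether phenethylcarbonyl and 3-phenylpropyl on an amine nitrogen in a ring differ at all in this assay stays open.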